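Chloro in place of methoxy: the next step in the series

A few compounds are considered here, and "the series" means these few. Any claim that something is new, unique, unknown or untested is made for them only; others in the source may bear on it.

Measured so far:
compound 1 `COc1cccc(N2CCN(CC(=O)N3CCN(c4nnc(-c5ccc(C)cc5)c(-c5ccc(C)cc5)n4)CC3)CC2)c1`, 867000 nM
compound 2 `COc1ccc(N2CCN(CC(=O)N3CCN(c4nnc(-c5ccc(C)cc5)c(-c5ccc(C)cc5)n4)CC3)CC2)cc1`, 53000 nM

For the measured compounds named here, compound 2 gives the lower of the two numbers in a functional assay on MCF7 cells (Homo sapiens) for cytotoxicity, read by MTT assay, with a stated time of 24 h; on this read-out higher numbers stand for weaker inhibition and lower numbers for stronger inhibition; its only neighbour is compound 1, and a 16-fold lower number from compound 1 to compound 2 (1.21 log units; beyond the scatter) separates them. Compound 3 `Cc1ccc(-c2nnc(N3CCN(C(=O)CN4CCN(c5ccc(Cl)cc5)CC4)CC3)nc2-c2ccc(C)cc2)cc1` differs from compound 2 by chloro in place of methoxy on an aromatic carbon. Going by the values given here, no measured step swaps a methoxy for a chloro; the single known step concerns only where the methoxy sits on the ring, so it gives no guide to direction or size here. A step of a 1.3-fold lower number from compound 2 to compound 3 (0.12 log units; within the scatter) is expected, with low confidence in either direction. The estimate for compound 3 is 40000 nM, with a range from 10000 nM to 160000 nM.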

Compound 3, half-maximal inhibitory concentration: 660000 nM
The estimate for compound 3 lay 17-fold (1.22 log units) below the measured number, outside the stated range (above it).
By their numbers in this assay, from the lowest: compound 2; then compounds 3 and 1 (each within the scatter of the next).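

In this assay, the aromatic carbon para to a large group responds to which group it carries, not only to where a methoxy sits: chloro in place of methoxy gives a 12-fold higher number from compound 2 to compound 3 (1.10 log units; beyond the scatter) on this carbon. The 4-chlorophenyl and 3-methoxyphenyl compounds stand level, with a 1.3-fold lower number from compound 1 to compound 3 (0.12 log units; within the scatter) between them, so compound 2 alone stands apart among the three. No measurement here accounts for the step.

Open, on these data alone, is whether an amine or fluoro on that carbon would read like methoxy or like chloro. Also open, as far as these compounds go, is whether a longer chain such as ethoxy would keep the number of compound 2.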